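Ethoxycarbonyl on the amino nitrogen of compound 2

The compounds below may be only part of what the source reports. "The series", "measured", "known", "first", "only" and "open" are said of these compounds alone.

Of the compounds shown here, three sharing one core have been measured in a functional assay on the whole organism for inhibition, with Mus musculus as the target; a higher number here means that more compound is needed for the effect, a lower number that less compound is needed. There, compound 1 `CN1Cc2c(N)cccc2C(c2ccc(Cl)cc2)C1` gives 1.1 mg/kg, compound 2 `CN1Cc2c(N)cccc2C(c2ccc(F)cc2)C1` gives 0.25 mg/kg and compound 3 `CC(C)c1ccc(C2CN(C)Cc3c(N)cccc32)cc1` gives 68 mg/kg. Compound 2 holds the lowest number of the three, and both of its steps lie beyond the scatter: a 4.4-fold lower number from compound 1 to compound 2 (0.64 log units; beyond the scatter) is modest, while a 270-fold higher number from compound 2 to compound 3 (2.43 log units; beyond the scatter) is large. The remaining step, a 62-fold higher number from compound 1 to compound 3 (1.79 log units; beyond the scatter), is also large.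

Compound 4 `CCOC(=O)Nc1cccc2c1CN(C)CC2c1ccc(F)cc1` differs from compound 2 in one place: ethoxycarbonyl in place of hydrogen on a nitrogen on an aromatic ring. In short, ethoxycarbonyl stands in place of hydrogen on a nitrogen on an aromatic ring. Going by the values given here, no measured step touches that nitrogen, since all three swap groups on an aromatic carbon, so they bear on this change only indirectly. They show that a single swap can move this assay a long way, as a 270-fold higher number from compound 2 to compound 3 (2.43 log units; beyond the scatter) does. A moderate rise with wide uncertainty is therefore expected, and the expected step is an 8.0-fold higher number from compound 2 to compound 4 (0.90 log units; beyond the scatter). For compound 4 the estimated value is 2 mg/kg, with an expected range of 0.25 mg/kg to 20 mg/kg.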

Compound 4, dose for half-maximal effect: 3.3 mg/kg
Beside the measured number, compound 4's estimate is 1.7-fold (0.22 log units) below it; the measured number falls inside the stated range.
By their numbers in this assay, from the lowest: compound 2; then compound 1; then compound 4; then compound 3.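

Going by these compounds alone, this is the first change at the amino nitrogen, and in this assay that position proves sensitive: replacing hydrogen with ethoxycarbonyl gives a 13-fold higher number from compound 2 to compound 4 (1.12 log units; beyond the scatter). Even so, the free amino hydrogen is not needed for a measurable effect, since compound 4 gives a dose of 3.3 mg/kg, and the step is smaller than the one at the aromatic carbon, a 270-fold higher number from compound 2 to compound 3 (2.43 log units; beyond the scatter). Nothing shown here accounts for the rise in dose.

The compounds shown leave open whether the loss follows from the whole ethoxycarbonyl group or could be lessened by something smaller on that nitrogen, such as acetyl or methyl. They also leave open whether ethoxycarbonyl would have a similar effect with chloro in place of fluoro on the aromatic carbon.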